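The source may hold more compounds than are shown below. What is called first, only, known or untested is meant among the compounds shown, and "the series" means these compounds.

Working notes on the series. Compound 1 `Cc1ccccc1C(=O)OC1(C(=O)Nc2ccc([N+](=O)[O-])cc2)CCCCC1` and compound 2 `O=C(OC1(C(=O)Nc2ccc([N+](=O)[O-])cc2)CCCCC1)c1ccccc1` share the same core and differ only at one aromatic carbon. In an ADME assay on WI-38 cells (Homo sapiens) for inhibition, read by MTT assay, with a stated time of 72 h (on this read-out higher numbers stand for weaker inhibition and lower numbers for stronger inhibition), compound 1 gives 352 nM, while compound 2 gives 246 nM; the step of a 1.4-fold lower number from compound 1 to compound 2 (0.16 log units; within the scatter) puts hydrogen in place of methyl on an aromatic carbon. Compound 2 stands lowest of the two numbers, with compound 1 nearest, and the gap between them is within the scatter, so no order between them is claimed.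

Compound 3 `O=COC1(C(=O)Nc2ccc([N+](=O)[O-])cc2)CCCCC1` differs from compound 2 by hydrogen in place of phenyl on a carbonyl carbon. Among the compounds with values here, the single measured step concerns a substituent on the ring that here leaves altogether, so it bears on this change only loosely, and because a 1.4-fold lower number from compound 1 to compound 2 (0.16 log units; within the scatter) stayed within the scatter it gives no direction of its own. Lacking a direct precedent, the expectation for compound 3 in this assay is a step of a 2.8-fold higher number from compound 2 to compound 3 (0.45 log units; beyond the scatter), toward a higher number, held with low confidence. The estimate for compound 3 in this assay is 700 nM, with a range from 200 nM to 2500 nM.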

Compound 3, half-maximal inhibitory concentration: 46.3 nM
Beside the measured number, compound 3's estimate is 15-fold (1.18 log units) above it; measured number below the stated range.
By their numbers in this assay, from the lowest: compound 3; then compounds 2 and 1 (each within the scatter of the next).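

In this assay the aromatic ring on this carbonyl carbon turns out not to be required for a low number: hydrogen in place of phenyl gives a 5.3-fold lower number from compound 2 to compound 3 (0.73 log units; beyond the scatter) and hydrogen in place of 2-methylphenyl gives a 7.6-fold lower number from compound 1 to compound 3 (0.88 log units; beyond the scatter), both beyond the scatter. Within the data shown here, the earlier pair varied only a methyl on that ring and gave no readable order, whereas benzoyl to formyl is the first change to move the number by more than the scatter. Nothing at hand accounts for the size or direction of this step.

The compounds shown go from an aromatic ring straight to hydrogen on this carbon, so it remains open where a small group such as methyl, or a longer chain, an amine or a carboxylic acid, would fall. As far as these compounds go, whether the same step holds on any core other than the shared one also remains open.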